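The compounds below may be only part of what the source reports. "The series", "measured", "known", "first", "only" and "open" are said of these compounds alone.

In a functional assay on cells (Cancer cell lines, Homo sapiens) for inhibition (a lower number here means a stronger inhibitor of growth, a higher number a weaker inhibitor of growth), compound 1 `N=C(N)N/N=C/c1c(-c2cc(Cl)sc2Cl)nc2n1CCS2` gives 17400 nM as its result. Compound 2 `N=C(N)N/N=C/c1c(-c2ccsc2)nc2sccn12` gives 28800 nM in this assay and these two values lie within the usual scatter of each other, which means that compound 1 cannot be ranked ahead of compound 2. Compound 3 `Cc1cc(-c2nc3n(c2/C=N/NC(=N)N)CCS3)c(C)s1` has not yet been measured and differs from compound 1 at one place 2,5-dimethylthiophen-3-yl in place of 2,5-dichlorothiophen-3-yl on an aromatic carbon with 2,5-dimethylthiophen-3-yl in place of 2,5-dichlorothiophen-3-yl on an aromatic carbon. Among the compounds with values here, no measured pair of compounds shows this exchange. The step expected in this assay is therefore none beyond the scatter, with neither direction favoured. The estimate amounts to a 1.1-fold higher number from compound 1 to compound 3 (0.06 log units; within the scatter) and no more than that. For compound 3 the estimated value is 20000 nM within an expected range of 9000 nM to 45000 nM overall.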

Compound 3, concentration for total growth inhibition: 34700 nM
Beside the measured number, compound 3's estimate is 1.7-fold (0.24 log units) below it, and the stated range covers the measured number.
By their numbers in this assay, from the lowest: compounds 1, 2 and 3 (each within the scatter of the next).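

Within the data shown here, this pair gives the first direct reading at this aromatic carbon of the shared core. In this assay, 2,5-dimethylthiophen-3-yl in place of 2,5-dichlorothiophen-3-yl gives a 2.0-fold higher number from compound 1 to compound 3 (0.30 log units; within the scatter), so exchanging these two groups, which have the same count of heavy atoms, does not separate the compounds in this read-out. No measurement bearing on the reason for this result is available.

The compounds shown carry only substituted or unsubstituted thiophen-3-yl groups at this place, so it remains open whether a phenyl ring, or a thiophene bearing an amine or a carboxylic acid, would give a step beyond the scatter. As far as these compounds go, it also remains open whether other substituents on the thiophene, such as a longer chain like hexyl, would do so.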